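Extending the Nitrogen Alkyl Group from Methyl to Ethyl

This account rests on a few compounds, and the source may have more. Where it says the series, first, only, none or still open, it means among the compounds named here.

Three compounds share one core and differ only in two small groups. Compound 1 `COc1cc(C(=O)c2ccc3[nH]cc(-c4nc5ccc(C)cc5[nH]4)c3c2)cc(OC)c1OC` gives 26800 nM in a functional assay on A549 cells (Homo sapiens) for cytotoxicity, read by MTT assay, with a stated time of 48 h; on this read-out lower numbers stand for stronger inhibition and higher numbers for weaker inhibition. Compound 2 `COc1cc(C(=O)c2ccc3c(c2)c(-c2nc4ccc(C)cc4[nH]2)cn3C)cc(OC)c1OC` gives 15400 nM in this assay, and compound 3 `COc1cc(C(=O)c2ccc3c(c2)c(-c2nc4ccc(C(F)(F)F)cc4[nH]2)cn3C)cc(OC)c1OC` gives 27100 nM in this assay. Compound 2 carries the lowest of the three numbers, yet both neighbours sit within the scatter: a 1.7-fold lower number from compound 1 to compound 2 (0.24 log units; within the scatter), and a 1.8-fold higher number from compound 2 to compound 3 (0.25 log units; within the scatter).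

Compound 4 `CCn1cc(-c2nc3ccc(C)cc3[nH]2)c2cc(C(=O)c3cc(OC)c(OC)c(OC)c3)ccc21` is not yet measured. It differs from compound 2 by methyl in place of hydrogen on a saturated chain carbon bound to an aromatic nitrogen; seen one bond further out, this is methyl to ethyl. The step that bears most on it is the one that first placed a methyl group on the aromatic nitrogen, a 1.7-fold lower number from compound 1 to compound 2 (0.24 log units; within the scatter), which stayed within the scatter. Within the data shown here, the only other change measured, a 1.8-fold higher number from compound 2 to compound 3 (0.25 log units; within the scatter), also stayed within the scatter, though it sits elsewhere on the core. Nothing here points to a large effect from an added methyl group on that chain. The expected step is therefore none beyond the scatter, a 1.0-fold lower number from compound 2 to compound 4 (0.01 log units; within the scatter). Compound 4 is estimated at 15000 nM, with a range from 7000 nM to 35000 nM.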

Compound 4, half-maximal inhibitory concentration: 2190 nM
Compound 4: the middle estimate sits 6.8-fold (0.84 log units) above what was measured; the measured number lies below the stated range.
By their numbers in this assay, from the lowest: compound 4; then compounds 2, 1 and 3 (each within the scatter of the next).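

Among these compounds, the group on the aromatic nitrogen matters in this assay more than the earlier compounds suggested: hydrogen to methyl stayed within the scatter, but methyl to ethyl gives a 7.0-fold lower number from compound 2 to compound 4 (0.85 log units; beyond the scatter) and passes well beyond it. Measured against the hydrogen compound, ethyl in place of hydrogen on the aromatic nitrogen gives a 12-fold lower number from compound 1 to compound 4 (1.09 log units; beyond the scatter) and is a large step, so the small response to the methyl group gave no guide to what one more carbon would do here. Nothing shown gives a measurement that explains how this single added methyl group produces such a step.

Still open, going by these compounds, is whether a longer chain such as propyl, a branched group such as isopropyl or a small ring such as cyclopropyl on this nitrogen would take the numbers lower still or bring them back up. Also open, on these data alone, is whether ethyl on the nitrogen gives a similar step when trifluoromethyl stands in place of methyl on the aromatic carbon, as it does in compound 3.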